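The source may report more compounds than this note shows. Statements on the series, on what has been measured and on what is new or still open speak of the compounds shown alone.

Measured so far in a functional assay on HEK293 cells for agonist activity at Vasopressin V2 receptor (Homo sapiens), read by a luciferase reporter and cAMP accumulation; a lower number here means that less compound is needed, a higher number that more compound is needed for the effect:
compound 1 `Cc1cc(C(=O)N2CCCCc3ccccc32)ccc1CNC(=O)Nc1c(F)cccc1F` gives 2.1 nM;
compound 2 `CCc1cc(C(=O)N2CCCCc3ccccc32)ccc1CNC(=O)Nc1c(F)cccc1F` gives 10 nM;
compound 3 `Cc1cc(C(=O)N2CCCCc3ccccc32)ccc1CNC(=O)NCC(=O)OC(C)C` gives 140 nM.

Compound 4 `Cc1cc(C(=O)N2CCCCc3ccccc32)ccc1CNC(=O)NCC(=O)OC(C)(C)C` is not yet measured. Compound 2 differs from compound 1 by methyl in place of hydrogen on a saturated chain carbon bound to an aromatic carbon, and that change gave a 4.8-fold higher number from compound 1 to compound 2 (0.68 log units; beyond the scatter). The cores of compound 1 and compound 3 differ by (isopropoxycarbonyl)methyl in place of 2,6-difluorophenyl on an amide-type nitrogen, which gave a 67-fold higher number from compound 1 to compound 3 (1.82 log units; beyond the scatter). From compound 3 to compound 4 the change is methyl in place of hydrogen on a saturated chain carbon bound to an oxygen next to a carbonyl group and two saturated chain carbons. This is the same kind of change as the earlier one, not the same: there the carbon is bound to an aromatic carbon, here to an oxygen next to a carbonyl group and two saturated chain carbons. Within the data shown here, the earlier step is the only guide, and its place is not this one. For compound 4 a smaller step is expected, a 1.4-fold higher number from compound 3 to compound 4 (0.15 log units; within the scatter), beside the earlier 4.8-fold higher number from compound 1 to compound 2 (0.68 log units; beyond the scatter). Compound 4 is therefore estimated at 200 nM, within 70 nM to 600 nM.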

Compound 4, half-maximal effective concentration: 120 nM
Compound 4: middle estimate off by 1.7-fold (0.22 log units), on the high side, within the range that was stated.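

In this assay, adding one methyl does not carry over as a fixed step from one core to the other, and the two cases differ by more than measurement scatter: the same change on two cores in this assay, a 4.8-fold higher number (0.68 log units; beyond the scatter) from compound 1 to compound 2 and a 1.2-fold lower number (0.07 log units; within the scatter) from compound 3 to compound 4, 5.6-fold (0.74 log units) apart, beyond the scatter of two such steps. On the new core, isopropyl to tert-butyl gives a 1.2-fold lower number from compound 3 to compound 4 (0.07 log units; within the scatter), whereas replacing 2,6-difluorophenyl with (tert-butoxycarbonyl)methyl gives a 57-fold higher number from compound 1 to compound 4 (1.76 log units; beyond the scatter), so the larger step remains the one tied to that replacement. These two methyl steps sit at different places, one on a carbon bound to an aromatic carbon and one on a carbon bound to an oxygen, so they cannot separate the effect of the place from that of the core, and they do not explain the gap.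

The compounds shown leave open how a carboxylic acid or a primary amide would read in place of the tert-butoxycarbonyl group. They also leave open whether a methyl added to the core of compound 3 at the carbon bound to an aromatic carbon would repeat the step seen on the core of compound 1.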